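Replacing a dimethylphenyl amide with a nitrophenyl amide

The source may hold more compounds than are shown below. What is called first, only, known or untested is meant among the compounds shown, and "the series" means these compounds.

Compound 2 `Cc1ccc(C)c(NC(=O)c2ccc(/N=N\c3c[nH]c4ccccc34)cc2)c1` gives 544000 nM in a functional assay on HCT-116 cells (Homo sapiens) for inhibition, read by MTT assay, with a stated time of 72 h; a higher number here means a weaker inhibitor, a lower number a stronger inhibitor. Its nearest neighbours are compound 3 `O=C(Nc1ccccc1F)c1ccc(/N=N\c2c[nH]c3ccccc23)cc1`, which gives 559000 nM, and compound 1 `Cc1cccc(NC(=O)c2ccc(/N=N\c3c[nH]c4ccccc34)cc2)c1C`, which gives 272000 nM; the steps of a 1.0-fold higher number from compound 2 to compound 3 (0.01 log units; within the scatter) and a 2.0-fold higher number from compound 1 to compound 2 (0.30 log units; within the scatter) both stay within the scatter, and only a 2.1-fold higher number from compound 1 to compound 3 (0.31 log units; beyond the scatter) edges modestly beyond it. Compound 4 `O=C(Nc1ccc([N+](=O)[O-])cc1)c1ccc(/N=N\c2c[nH]c3ccccc23)cc1` differs from compound 2 by 4-nitrophenyl in place of 2,5-dimethylphenyl on an amide-type nitrogen. Each measured step here alters the same aryl group on the amide nitrogen, and none of them moved the numbers far, so this swap is expected to give a step of about a 1.1-fold lower number from compound 2 to compound 4 (0.04 log units; within the scatter), that is, nothing beyond the scatter. Compound 4 is therefore estimated at 500000 nM, within a range of 150000 nM to 1500000 nM.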

Compound 4, half-maximal inhibitory concentration: 156000 nM
Compound 4: the middle estimate sits 3.2-fold (0.51 log units) above what was measured; the measured number falls inside the stated range.
By their numbers in this assay, from the lowest: compounds 4, 1, 2 and 3 (each within the scatter of the next, the first and the last beyond it).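

In this assay, the aryl group on the amide-type nitrogen can shift the number clearly beyond the scatter: 4-nitrophenyl gives a 3.5-fold lower number from compound 2 to compound 4 (0.54 log units; beyond the scatter) and a 3.6-fold lower number from compound 3 to compound 4 (0.55 log units; beyond the scatter). The gain is not clean across the series, since a 1.7-fold lower number from compound 1 to compound 4 (0.24 log units; within the scatter) leaves compound 4 not separable from compound 1. Nothing available here accounts for this shift.

The compounds shown leave open whether 4-aminophenyl or 4-carboxyphenyl in place of 4-nitrophenyl on the amide-type nitrogen would keep these steps.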